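The source may hold more compounds than are shown below. What is called first, only, known or untested is meant among the compounds shown, and "the series" means these compounds.

Working notes on the series. Of the compounds shown here, three on a shared core have been measured: compound 1, `CC#C[C@@H](Cc1nnn[nH]1)c1ccc(OCc2ccc3scc(-c4cncnc4C)c3c2)cc1`, compound 2, `CC#C[C@@H](Cc1nnn[nH]1)c1ccc(OCc2ccc3scc(-c4ccccc4C(F)(F)F)c3c2)cc1`, and compound 3, `CC#C[C@@H](Cc1nnn[nH]1)c1ccc(OCc2ccc3scc(-c4ccc(OCCOC)cc4C)c3c2)cc1`. In an ADME assay on microsomes from liver (Rattus norvegicus) for metabolic stability (a lower number here means that the compound disappears faster, a higher number that the compound lasts longer), compound 1 gives 0.333 h, compound 2 gives 0.167 h and compound 3 gives 0.217 h. The three exchanges at the one varied position all stay within scatter: a 2.0-fold lower number from compound 1 to compound 2 (0.30 log units; within the scatter), a 1.5-fold lower number from compound 1 to compound 3 (0.19 log units; within the scatter) and a 1.3-fold higher number from compound 2 to compound 3 (0.11 log units; within the scatter). Compound 3 therefore sits among values that cannot be told apart, closest to compound 2 and furthest from compound 1, both gaps within scatter.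

Compound 4, `CC#C[C@@H](Cc1nnn[nH]1)c1ccc(OCc2ccc3sc(C(F)(F)F)c(-c4ccc(OCCOC)cc4C)c3c2)cc1`, differs from compound 3 by trifluoromethyl in place of hydrogen on an aromatic carbon, placed on an aromatic carbon of a five-membered aromatic ring with one sulfur, next to the ring sulfur and next to the ring atom that bears the 4-(2-methoxyethoxy)-2-methylphenyl group. Within the data shown here, no measured step touches this position; the three known steps all concern the other exchanged group and none of them leaves the scatter. Among the measured compounds shown here, there is no step to carry over, so in this assay the expected change is a 1.2-fold higher number from compound 3 to compound 4 (0.06 log units; within the scatter), nothing beyond the scatter. Compound 4 is estimated at 0.25 h, in the range 0.1 h to 0.6 h.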

Compound 4, half-life: > 3 h
Compound 4: no number, only a limit (the forecaster's own chance of this, stated with the estimate: 5%); middle value at least 12-fold (1.07 log units) from the limit.
By their numbers in this assay, from the lowest: compounds 2, 3 and 1 (each within the scatter of the next). At a limit, above all of these: compound 4.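

In this assay, among these compounds, trifluoromethyl in place of hydrogen, on the aromatic carbon next to the ring sulfur, gives an at least 13-fold higher number from compound 3 to compound 4 (1.14 log units; beyond the scatter) and is the first exchange to leave the scatter. The three exchanges among compounds 1, 2 and 3 all concern the group on the neighbouring ring atom and all stay within the scatter, so on this single pair the position next to the ring sulfur is the one that moves the half-life. Compound 4 gives > 3 h as a limit of the assay and not as a number: the limit of > 3 h in this assay, at which 1 of the 4 values shown sits.

From the compounds shown here alone, the step rests on one pair, so it stays open whether it holds with 4-methylpyrimidin-5-yl or 2-(trifluoromethyl)phenyl on the neighbouring ring atom. Also open, going by these compounds, is what a different group at this position, such as a methyl, a nitrile or an amine, would do to the half-life.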